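This account rests on a few compounds, and the source may have more. Where it says the series, first, only, none or still open, it means among the compounds named here.

Measured so far in an assay on HEK293 cells for agonist activity at probable G-protein coupled receptor 34 (Mus musculus), with a stated time of 1 h; a lower number here means a smaller maximal response, a higher number a larger maximal response:
- compound 1, `CCCCCCCC/C=C\CCCCCCCC(=O)OC[C@@H](C)OP(=O)(O)OC[C@H](N)C(=O)O`: 12.8%
- compound 2, `CCCCCCCC/C=C\CCCCCCCC(=O)OC[C@H](C)OP(=O)(O)OC[C@H](N)C(=O)O`: 11.2%
- compound 3, `CCCCCCCC/C=C\CCCCCCCC(=O)O[C@@H](C)COP(=O)(O)OC[C@H](N)C(=O)O`: "not active" (no number reported)

Compound 1 holds the larger of the two reported numbers in this assay, but the gap to compound 2, a number 1.6 percentage points lower from compound 1 to compound 2 (within the scatter), lies within the scatter, so the two cannot be separated; that pair differs only in how the chain stereocentre is drawn (the fact that one of compounds 1 and 2 is drawn with a defined configuration and the other without, at the place where they differ). Compound 3 carries the acyl chain on the other oxygen and is reported without a number.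

The next compound is compound 4, `CCCCCCCC/C=C\CCCCCCCC(=O)OC[C@@H](COCCC)OP(=O)(O)OC[C@H](N)C(=O)O`. Its change from compound 1 is propoxy in place of hydrogen on a saturated chain carbon, two bonds along the chain from an oxygen on an unsaturated carbon. Going by the values given here, none of the measured steps touches this position or adds a group of this kind; the only measured step, the stereo inversion from compound 1 to compound 2, stayed within the scatter and says nothing about a propoxy group. Among the compounds with values here, with no step to lean on, the expectation is a maximal response near that of compound 1, and the step of a number 0.8 percentage points lower from compound 1 to compound 4 (within the scatter) is expected to stay within the scatter. Compound 4 is estimated at 12%, in the range 0% to 30%.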

Compound 4, largest response reached (Emax), in percent of the reference or control that the assay uses: 12.2%
For compound 4 the middle estimate is 0.2 percentage points below the measured one; the range from low to high includes it.
By their numbers in this assay, from the lowest: compounds 2, 4 and 1 (each within the scatter of the next).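

In this assay, propoxy in place of hydrogen on a saturated chain carbon, two bonds along the chain from an oxygen on an unsaturated carbon, gives a number 0.6 percentage points lower from compound 1 to compound 4 (within the scatter). Going by these compounds alone, compounds 1 to 3 all carry a plain methyl here, so compound 4 is the first to show that this carbon can bear propoxymethyl with a maximal response that cannot be separated from that of compound 1. Nothing measured here gives a reason for this step.

From the compounds shown here alone, whether an amine, a carboxylic acid or a longer chain at this place would move the maximal response beyond the scatter remains open. Also open, going by these compounds, are the outcome of inverting the stereocentre with propoxymethyl present and of moving the acyl chain to the other oxygen, as in compound 3.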